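A few compounds are considered here, and "the series" means these few. Any claim that something is new, unique, unknown or untested is made for them only; others in the source may bear on it.

In a functional assay on the whole organism (strain albino) with Mus musculus as the target, in the maximal electroshock model, with a stated time of 0.5 h (a lower number here means that less compound is needed, a higher number that more compound is needed for the effect), compound 3 `Cc1ccccc1Nc1nnc(Nc2nc(-c3ccccc3)cs2)s1` gives 300 mg/kg, the highest of the three numbers, sitting a 3.0-fold higher number from compound 1 to compound 3 (0.48 log units; beyond the scatter) and above compound 2 `COc1ccc(Nc2nnc(Nc3nc(-c4ccc([N+](=O)[O-])cc4)cs3)s2)cc1`, which gives 30 mg/kg. Compound 1 `Cc1ccccc1Nc1nnc(Nc2nc(-c3ccc([N+](=O)[O-])cc3)cs2)s1` gives 100 mg/kg. Compound 4 `COc1ccc(Nc2nnc(Nc3nc(-c4ccccc4)cs3)s2)cc1` differs from compound 3 by 4-methoxyphenyl in place of 2-methylphenyl on a nitrogen on an aromatic ring. For the measured compounds named here, one measured step bears on this change directly: a 3.3-fold lower number from compound 1 to compound 2 (0.52 log units; beyond the scatter) on the nitro-bearing core. If that step carries over to the core of compound 3, compound 4 is expected to need a comparably smaller dose, a 3.0-fold lower number from compound 3 to compound 4 (0.48 log units; beyond the scatter), though with one prior example the size is uncertain. Compound 4 is therefore estimated at 100 mg/kg, with a range from 30 mg/kg to 300 mg/kg.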

Compound 4, minimum effective dose: 100 mg/kg
Beside the measured number, compound 4's estimate shows no gap at the digits printed; the measured number falls inside the stated range.
By their numbers in this assay, from the lowest: compound 2; then compounds 1 and 4 (each within the scatter of the next); then compound 3.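

In this assay, 4-methoxyphenyl in place of 2-methylphenyl on a nitrogen on an aromatic ring gives a 3.0-fold lower number from compound 3 to compound 4 (0.48 log units; beyond the scatter), so the change now recurs on a second core at a matching size: the same change on two cores in this assay, a 3.3-fold lower number (0.52 log units; beyond the scatter) from compound 1 to compound 2 and a 3.0-fold lower number (0.48 log units; beyond the scatter) from compound 3 to compound 4, 1.1-fold (0.05 log units) apart, within the scatter of two such steps. Hydrogen in place of nitro gives a 3.3-fold higher number from compound 2 to compound 4 (0.52 log units; beyond the scatter), and this change also recurs: the same change on two cores in this assay, a 3.0-fold higher number (0.48 log units; beyond the scatter) from compound 1 to compound 3 and a 3.3-fold higher number (0.52 log units; beyond the scatter) from compound 2 to compound 4, 1.1-fold (0.05 log units) apart, within the scatter of two such steps. Across these four compounds, the size of each change does not depend on the other.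

The compounds shown leave open what a plain phenyl on that nitrogen would give, so the separate shares of the methyl and methoxy groups in the step remain unknown. On these data alone, how an amine in place of nitro would stand is also open.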